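This account rests on a few compounds, and the source may have more. Where it says the series, first, only, none or still open, it means among the compounds named here.

Working notes on the series. All compounds share a core in which an arylsulfonamide nitrogen carries a 2-alkylphenyl group and the sulfonyl-bearing ring carries a chloropropyl urea; the compounds divide into two cores, that of compound 1 and that of compound 3, and the difference between the two cores is not broken down here.

Compound 1 `CCc1ccccc1NS(=O)(=O)c1cccc(NC(=O)NCCCCl)c1` is measured in a functional assay on HT-29 cells (Homo sapiens) for cytotoxicity, read by sulforhodamine B assay, with a stated time of 48 h (a higher number here means a weaker inhibitor, a lower number a stronger inhibitor), at 96000 nM. Compound 2 `CCCc1ccccc1NS(=O)(=O)c1cccc(NC(=O)NCCCCl)c1` differs from compound 1 by methyl in place of hydrogen on a saturated chain carbon, two bonds along the chain from an aromatic carbon. In this assay compound 2 gives 15000 nM, a step of a 6.4-fold lower number from compound 1 to compound 2 (0.81 log units; beyond the scatter).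

Compound 3 `CCc1ccccc1NS(=O)(=O)c1ccc(NC(=O)NCCCCl)cc1` has the same atoms as compound 1 joined differently. In this assay compound 3 reports only a limit, > 200000 nM, and no number.

Compound 4 `CCCc1ccccc1NS(=O)(=O)c1ccc(NC(=O)NCCCCl)cc1` is not yet measured in this assay. Compound 4 differs from compound 3 by methyl in place of hydrogen on a saturated chain carbon, two bonds along the chain from an aromatic carbon, the same change as that from compound 1 to compound 2, at the same place by the same words. Its step cannot be sized from a measured starting point because the limit of > 200000 nM in this assay, at which 1 of the 3 values shown sits, is where compound 3 stands; only the lower end of the start is known. Carrying the step of a 6.4-fold lower number from compound 1 to compound 2 (0.81 log units; beyond the scatter) over to the core of compound 3 is expected to give, at most, a step of an at least 3.3-fold lower number from compound 3 to compound 4 (0.52 log units; beyond the scatter) from compound 3 to compound 4, and a second limit is a real possibility. Compound 4 is expected to fall near 60000 nM in this assay, within a range of 20000 nM to 200000 nM.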

Compound 4, half-maximal inhibitory concentration: 26000 nM
For compound 4 the middle estimate is 2.3-fold (0.36 log units) above the measured one, within the range that was stated.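

On the core of compound 3, 2-propylphenyl in place of 2-ethylphenyl gives an at least 7.6-fold lower number from compound 3 to compound 4 (0.88 log units; beyond the scatter) in this assay, so the change lowers the number in the same direction on both cores shown. Set beside the earlier step, the comparison reads: the same change on two cores in this assay, a 6.4-fold lower number (0.81 log units; beyond the scatter) from compound 1 to compound 2 and an at least 7.6-fold lower number (0.88 log units; beyond the scatter) from compound 3 to compound 4; the limit leaves it open whether they differ

Compound 3 is held only by a limit, > 200000 nM, so the new step has a known minimum and no known size, and equal steps on the two cores are neither shown nor excluded: the limit of > 200000 nM in this assay, at which 1 of the 4 values shown sits.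

The carry-over therefore rests on one change and two pairs of compounds, and it supports a shared direction rather than a transferable size.

From the compounds shown here alone, whether a longer chain than propyl on the phenyl group lowers the number further on either core remains open, as does the outcome for a branched chain such as isopropyl. Also open, going by these compounds, is how either core responds when an amine or a carboxylic acid stands at the end of that chain, or when another group takes the place of the chloropropyl chain on the urea.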